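Swapping Methoxy for Methyl: A Half-Life Estimate

This account rests on a few compounds, and the source may have more. Where it says the series, first, only, none or still open, it means among the compounds named here.

Compound 1 `COc1ccnc(C[S+]([O-])c2nc3cc(OC(F)(F)C(F)F)ccc3[nH]2)c1` gives 0.8 h
Compound 2 `COc1ccnc(C[S+]([O-])c2nc3cc(F)c(OC(F)F)cc3[nH]2)c1OC` gives 8.3 h

In an ADME assay, at pH 5 (a higher number here means that the compound lasts longer, a lower number that the compound disappears faster), compound 2 stands highest of the two, at 8.3 h, well beyond the scatter from compound 1. Compound 3 `COc1ccnc(C[S+]([O-])c2nc3cc(F)c(OC(F)F)cc3[nH]2)c1C` has methyl in place of methoxy on an aromatic carbon and otherwise matches compound 2. Among the measured compounds shown here, no measured pair shows this change, so any expectation here is a judgement. A drop beyond the scatter is expected in this assay, and the estimated step runs a 2.6-fold lower number from compound 2 to compound 3 (0.41 log units; beyond the scatter) overall. For compound 3 the expected half-life is 3.2 h, within an estimated range from 1.5 h to 6.5 h overall.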

Compound 3, half-life: 0.5 h
Compound 3: the middle estimate sits 6.4-fold (0.81 log units) above what was measured, and the stated range ends above it.
By their numbers in this assay, from the lowest: compounds 3 and 1 (each within the scatter of the next); then compound 2.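

In this assay the place two atoms from the ring nitrogen proves sensitive: methyl in place of methoxy there gives a 17-fold lower number from compound 2 to compound 3 (1.22 log units; beyond the scatter) and so removes most of the half-life that compound 2 holds. Among the compounds shown here, compound 1 and compound 2 differ in more than one place, so only this pair isolates the methoxy group on this aromatic carbon. No evidence at hand bears on why the step is so large. As far as these compounds go, whether an ethoxy group or an amine at this place would stand nearer compound 2 or compound 3 stays open. So does whether the step would carry over to the core of compound 1.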